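The source may report more compounds than this note shows. Statements on the series, on what has been measured and on what is new or still open speak of the compounds shown alone.

Measured in a physicochemical assay for solubility, read by HPLC, in simulated intestinal fluid, with a stated time of 16 h, tested at 125 ug/mL; on this read-out higher numbers stand for higher solubility and lower numbers for lower solubility:
- Compound 1 `CNC(=O)c1cc(C(=O)NC2CC2)cn(Cc2ccc(F)cc2)c1=O` gives 84 ug/mL
- Compound 2 `CNC(=O)c1cc(C(=O)NC2CC2)cn(Cc2ccc(C)cc2)c1=O` gives 11 ug/mL
- Compound 3 `CNC(=O)c1cc(C(=O)NC2CC2)cn(Cc2cccc(F)c2)c1=O` gives 31 ug/mL

Compound 3 stands second highest of these three numbers. Compound 4 `CNC(=O)c1cc(C(=O)NC2CC2)cn([C@H](C)c2ccccc2)c1=O` has not yet been measured. In it, 1-phenylethyl replaces 3-fluorobenzyl on an aromatic nitrogen 1-phenylethyl in place of 3-fluorobenzyl on an aromatic nitrogen and brings a defined stereocentre. Within the data shown here, no measured step makes this exact change. The closest are those that alter the aromatic group: a 7.6-fold lower number from compound 1 to compound 2 (0.88 log units; beyond the scatter), a 2.7-fold lower number from compound 1 to compound 3 (0.43 log units; beyond the scatter) and a 2.8-fold higher number from compound 2 to compound 3 (0.45 log units; beyond the scatter). All three are modest, though beyond the scatter, and they point in no single direction for this change. So no clear step is expected, and the estimate stays close to compound 3: a 1.0-fold lower number from compound 3 to compound 4 (0.01 log units; within the scatter). Compound 4 is expected to give about 30 ug/mL, within an estimated range of 10 ug/mL to 90 ug/mL.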

Compound 4, solubility: 815 ug/mL
Estimate against measurement, compound 4: 27-fold (1.43 log units) below, outside the stated range (above it).
By their numbers in this assay, from the lowest: compound 2; then compound 3; then compound 1; then compound 4.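

In this assay, the group on the aromatic nitrogen can shift the number much further than the earlier ring changes did: a 26-fold higher number from compound 3 to compound 4 (1.42 log units; beyond the scatter), with a 74-fold higher number from compound 2 to compound 4 (1.87 log units; beyond the scatter) and a 9.7-fold higher number from compound 1 to compound 4 (0.99 log units; beyond the scatter) pointing the same way. Compound 4, with its branched 1-phenylethyl group, thus stands above all three benzyl compounds, whichever ring substituent they carry. Nothing measured here explains this rise.

On these data alone, whether the rise belongs to the added methyl on the chain carbon, the defined stereocentre or the phenyl ring without fluoro or methyl stays open. So does what a longer chain such as 1-phenylpropyl, or an amine on the phenyl ring, would give.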